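Dibromothiophene in Place of Methylsulfanylthiophene on the Sulfonylurea

The compounds below may be only part of what the source reports. "The series", "measured", "known", "first", "only" and "open" are said of these compounds alone.

Compound 1 `CSc1ccc(S(=O)(=O)NC(=O)Nc2ccc(Cl)cc2)s1` gives 29% in a functional assay on the whole organism (6C3HED cells, Mus musculus) for inhibition, at a dose of 150 mg/kg by the oral route (a higher number here means more inhibition at the dose given (going by the name of the read-out), a lower number less inhibition), the lowest of the three numbers shown. Compound 3 `CCCc1ccc(S(=O)(=O)NC(=O)Nc2ccc(Cl)cc2)s1` gives 38%, and a number 9 percentage points higher from compound 1 to compound 3 (within the scatter). Compound 2 `CCOc1ccc(S(=O)(=O)NC(=O)Nc2ccc(Cl)cc2)s1` gives 69%, and a number 40 percentage points higher from compound 1 to compound 2 (beyond the scatter). Compound 4 `O=C(Nc1ccc(Cl)cc1)NS(=O)(=O)c1cc(Br)c(Br)s1` differs from compound 1 by 4,5-dibromothiophen-2-yl in place of 5-(methylsulfanyl)thiophen-2-yl on a sulfonyl sulfur. For the measured compounds named here, none of the measured steps involves bromine, and none bears directly on this change; they show only that exchanging the group on this ring can leave the read-out within the scatter or raise it by a large amount. The direction of the step for compound 4 is therefore not fixed by the data, and a moderate rise is expected as a middle case. Compound 4 is estimated at 45%, in a range from 15% to 75%. This amounts to an expected a number 16 percentage points higher from compound 1 to compound 4 (beyond the scatter).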

Compound 4, a percentage reported as inhibition, in the whole organism at one dose (the size of the read-out at that dose, not a potency): 25%
The estimate for compound 4 lay 20 percentage points above the measured number; measured number inside the range.
By their numbers in this assay, from the lowest: compounds 4, 1 and 3 (each within the scatter of the next, the first and the last beyond it); then compound 2.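

In this assay, 4,5-dibromothiophen-2-yl in place of 5-(methylsulfanyl)thiophen-2-yl on a sulfonyl sulfur gives a number 4 percentage points lower from compound 1 to compound 4 (within the scatter). The earlier compounds shown here showed exchanges of a single group on this ring only; compound 4 shows that a ring carrying two bromine atoms also stays within the scatter of compound 1. Nothing measured here explains this result. The compounds shown leave open how a ring with a single bromine would read, and whether an amine or a carboxylic acid there could approach compound 2 at 69%.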